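Expecting compound 4 from three level cytotoxicity values

The compounds below may be only part of what the source reports. "The series", "measured", "known", "first", "only" and "open" are said of these compounds alone.

Compound 1 `COc1cc(C2=NOC(COc3ccc(-c4nnnn4-c4cc(OC)c(OC)c(OC)c4)cc3N)C2)cc(OC)c1OC` gives 3230 nM
Compound 2 `COc1ccc(-c2nnnn2-c2cc(OC)c(OC)c(OC)c2)cc1N` gives 3170 nM
Compound 3 `COc1ccc(C2=NOC(COc3ccc(-c4nnnn4-c4cc(OC)c(OC)c(OC)c4)cc3N)C2)cc1[N+](=O)[O-]` gives 3560 nM

These values come from a functional assay on MDA-MB-231 cells (Homo sapiens) for cytotoxicity, read by MTT assay, with a stated time of 48 h (on this read-out higher numbers stand for weaker inhibition and lower numbers for stronger inhibition), and lie within the scatter of one another, so compound 3 (3560 nM) holds no distinct rank among the three. Compound 4 `COc1cc(-n2nnnc2-c2ccc(OCC3CC(c4ccccc4F)=NO3)c(N)c2)cc(OC)c1OC` has not yet been measured. It carries 2-fluorophenyl in place of 4-methoxy-3-nitrophenyl on a carbon with a double bond to nitrogen. Going by the values given here, the only measured change at that carbon is a 1.1-fold higher number from compound 1 to compound 3 (0.04 log units; within the scatter) (4-methoxy-3-nitrophenyl in place of 3,4,5-trimethoxyphenyl). Compound 2, which has neither that carbon nor its aryl group, gives much the same number (3170 nM). Among the compounds with values here, no measured compound carries 2-fluorophenyl, so this group itself is untested and the range must stay wide. On this evidence, the expected step is a 1.1-fold lower number from compound 3 to compound 4 (0.03 log units; within the scatter) and no change beyond the scatter is anticipated in either direction. Compound 4 is estimated at 3300 nM (expected range 1600 nM to 6500 nM).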

Compound 4, half-maximal inhibitory concentration: 2400 nM
Compound 4: the middle estimate sits 1.4-fold (0.14 log units) above what was measured, within the range that was stated.
By their numbers in this assay, from the lowest: compounds 4, 2, 1 and 3 (each within the scatter of the next).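

In this assay, 2-fluorophenyl in place of 4-methoxy-3-nitrophenyl on the carbon with a double bond to nitrogen gives a 1.5-fold lower number from compound 3 to compound 4 (0.17 log units; within the scatter), and 2-fluorophenyl in place of 3,4,5-trimethoxyphenyl gives a 1.3-fold lower number from compound 1 to compound 4 (0.13 log units; within the scatter), so an aryl group with neither methoxy nor nitro substituents also leaves the number within the scatter. The full group of 12 heavy atoms, including 2-fluorophenyl, in place of a hydrogen atom gives a 1.3-fold lower number from compound 2 to compound 4 (0.12 log units; within the scatter), which extends the same flat picture to a third comparison. No measurement is available that would explain these small differences.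

Still open, from the compounds shown here alone, is whether something other than an aryl group on that carbon, such as a carboxylic acid or a morpholine, would move the number beyond the scatter. Equally open, going by these compounds, is whether chlorine in place of the fluorine of 2-fluorophenyl would leave it level.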